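The source may report more compounds than this note shows. Statements on the series, on what has been measured and on what is new or still open speak of the compounds shown alone.

Compound 2, `N/C(=N\NC(=S)N1CCSCC1)c1ccccn1`, is one of two measured compounds, and in a functional assay on A-375 cells (Homo sapiens) for cytotoxicity, read by MTT assay, with a stated time of 72 h, tested at 3 uM (on this read-out lower numbers stand for less inhibition of growth and higher numbers for more inhibition of growth at the one concentration tested), compound 2 gives 80%. For the measured compounds named here, the only other measured compound, compound 1, `N/C(=N\NC(=S)N1CCCC1)c1ccc(F)cn1`, differs from compound 2 in more than one place, so their two numbers can only be set side by side: in this assay compound 1 gives 81.8%, and the gap to compound 2 lies within the usual scatter, so the two numbers are treated as one level of growth inhibition. Compound 3, `N/C(=N\NC(=S)N1CCSCC1)c1ccc(F)cn1`, is built from compound 2 by the change (fluoro in place of hydrogen on an aromatic carbon). Going by the values given here, no step between measured compounds is available for this change alone. Since the two measured numbers sit at the same level, compound 3 is expected to show no step beyond the scatter, that is a number 1 percentage points higher from compound 2 to compound 3 (within the scatter). Compound 3 is therefore estimated at 81%, with a range from 70% to 91%.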

Compound 3, percent growth inhibition at one concentration: 62.2%
Compound 3: the middle estimate sits 18.8 percentage points above what was measured; the measured number lies below the stated range.
By their numbers in this assay, from the lowest: compound 3; then compounds 2 and 1 (each within the scatter of the next).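

In this assay, fluoro on this aromatic carbon, two atoms from the ring nitrogen and para to a large group, is not a silent change when thiomorpholin-4-yl sits on the thiocarbonyl carbon: it gives a number 17.8 percentage points lower from compound 2 to compound 3 (beyond the scatter). With fluoro held in place, the other single change, thiomorpholin-4-yl in place of pyrrolidin-1-yl on the thiocarbonyl carbon, gives a number 19.6 percentage points lower from compound 1 to compound 3 (beyond the scatter), so the growth inhibition at this one concentration responds to both places. Nothing available speaks to the reason for either step.

Whether fluoro has a comparable effect when pyrrolidin-1-yl sits on the thiocarbonyl carbon remains open, since the compounds shown offer no such pair. Going by these compounds, it is also open how a chlorine atom or a methoxy group on the same aromatic carbon would compare with fluoro.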